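Swapping 4-carbamoylphenyl for 2,4-difluorophenyl

The source may report more compounds than this note shows. Statements on the series, on what has been measured and on what is new or still open speak of the compounds shown alone.

Measured in a functional assay on Jurkat cells (Homo sapiens); a lower number here means a stronger inhibitor, a higher number a weaker inhibitor:
compound 1 `CC(C)[C@H](NC(=O)COc1cccc2ccccc12)C(=O)N[C@@H](CC(=O)O)C(=O)COc1ccc(-c2ccccc2)cc1` gives 87900 nM
compound 2 `CC(C)[C@H](NC(=O)COc1cccc2ccccc12)C(=O)N[C@@H](CC(=O)O)C(=O)COc1ccccc1C(F)(F)F` gives > 100000 nM (a limit)
compound 3 `CC(C)[C@H](NC(=O)COc1cccc2ccccc12)C(=O)N[C@@H](CC(=O)O)C(=O)COc1ccc(C(N)=O)cc1` gives > 100000 nM (a limit)

Compound 3 yields only a limit and no number. The series crowds at the limit of > 100000 nM in this assay, at which 2 of the 3 values shown sit. Compound 4 `CC(C)[C@H](NC(=O)COc1cccc2ccccc12)C(=O)N[C@@H](CC(=O)O)C(=O)COc1ccc(F)cc1F` differs from it by 2,4-difluorophenyl in place of 4-carbamoylphenyl on an oxygen on a saturated carbon, with 2,4-difluorophenyl in place of 4-carbamoylphenyl on an oxygen on a saturated carbon. The bearing steps give only floors: an at least 1.1-fold higher number from compound 1 to compound 3 (0.05 log units; that floor lies within the scatter) and an at least 1.1-fold higher number from compound 1 to compound 2 (0.05 log units; that floor lies within the scatter) both lie within the scatter, while a step that the two limits leave unreadable from compound 2 to compound 3 cannot be read. Going by the values given here, a large step is therefore not expected in this assay, only a modest fall at best, since compound 1 gives 87900 nM as the sole true number. The estimated step is an at least 1.2-fold lower number from compound 3 to compound 4 (0.09 log units; that floor lies within the scatter). Compound 4 is expected at 80000 nM, within an estimated range of 20000 nM to 150000 nM.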

Compound 4, half-maximal inhibitory concentration: 33200 nM
Compound 4: middle estimate off by 2.4-fold (0.38 log units), on the high side; the range from low to high includes it.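

In this assay, 2,4-difluorophenyl on an oxygen on a saturated carbon gives the series its second true number and shows that a change at this position can reach beyond the scatter, with a 2.6-fold lower number from compound 1 to compound 4 (0.42 log units; beyond the scatter). Against the two compounds held at a limit, the steps are floors: an at least 3.0-fold lower number from compound 3 to compound 4 (0.47 log units; beyond the scatter) and an at least 3.0-fold lower number from compound 2 to compound 4 (0.47 log units; beyond the scatter), which makes compound 4 the strongest of the four. The other values still crowd at the top of the range: the limit of > 100000 nM in this assay, at which 2 of the 4 values shown sit.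

The compounds shown leave open whether both fluorines are needed, and whether a chlorine or a nitrile on the phenyl ring would serve as well.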